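The compounds below may be only part of what the source reports. "The series", "measured", "known", "first", "only" and "open" are said of these compounds alone.

Compound 1 `COc1ccc(-c2cnc(NC(=O)c3ncc[nH]3)n2C)cc1` carries a 1H-imidazol-2-yl amide on the shared core. In an ADME assay on microsomes from liver (Homo sapiens) for metabolic stability (a higher number here means faster removal of the compound, a lower number slower removal), compound 1 gives < 7 uL/min, which is a limit of the assay and not a number, so compound 1 sits at the floor of what the numbers show, with the limit of < 7 uL/min in this assay, at which 1 of the 2 values shown sits. For the measured compounds named here, compound 2 `COc1ccc(-c2cnc(NC(=O)c3ccc(F)cc3)n2C)cc1` is the only measured neighbour, and in this assay compound 2 gives 30 uL/min. Going by the values given here, the single measured step, an at least 4.2-fold higher number from compound 1 to compound 2 (0.63 log units; beyond the scatter), concerns the amide side of the molecule and not the aryl ring. Compound 3 `Cn1c(-c2ccc(Cl)cc2)cnc1NC(=O)c1ncc[nH]1` differs from compound 1 by chloro in place of methoxy on an aromatic carbon. Among the compounds with values here, no measured step touches that position, so the only guide is the standing of compound 1 at its limit. No step beyond the scatter is expected for compound 3. The estimate for compound 3 is 5 uL/min, between 2 uL/min and 12 uL/min. The expected step is a step that the limit leaves unreadable from compound 1 to compound 3, and a further limit reading for compound 3 remains likely.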

Compound 3, intrinsic clearance in a liver preparation (reported as CLH), per the amount of preparation that the assay uses in the Homo sapiens assay: < 7 uL/min
Compound 3: no number, only a limit (the forecaster's own chance of this, stated with the estimate: 60%); the middle value lies beyond the limit too.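

Compound 1 and compound 3 both sit at a limit in the Homo sapiens assay, and no new step can be read between them. In a physicochemical assay for solubility, read by nephelometry, measured as kinetic solubility, at pH 2.0 (on this read-out lower numbers stand for lower solubility and higher numbers for higher solubility), compound 1 gives > 100 ug/mL, which is a limit of the assay. In the physicochemical assay compound 3 gives 50 ug/mL, which makes an at least 2.0-fold lower number from compound 1 to compound 3 (0.30 log units; that floor lies within the scatter). The compounds shown leave open how far compound 1 and compound 3 lie from the shared limit on removal, and whether chloro in place of methoxy shifts that read-out at all.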